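The source may hold more compounds than are shown below. What is called first, only, known or untested is meant among the compounds shown, and "the series" means these compounds.

Measured in an ADME assay on microsomes from liver (Rattus norvegicus) for metabolic stability, read by LC-MS, using NADPH, tested at 3 uM; a lower number here means that the compound disappears faster, a higher number that the compound lasts longer:
- Compound 1 `N#CCC(c1ccccc1)c1c(-c2ccccc2)[nH]c2cc(Cl)ccc12`: 0.375 h
- Compound 2 `FC(F)(F)CC(c1ccco1)c1c(-c2ccccc2)[nH]c2cc(Cl)ccc12`: 0.772 h

Of these two numbers, compound 2 stands highest at 0.772 h, beyond the usual scatter from compound 1. Compound 3 `FC(F)(F)CC(c1ccccc1)c1c(-c2ccccc2)[nH]c2cc(Cl)ccc12` carries phenyl in place of furan-2-yl on a saturated chain carbon bound to an aromatic carbon and a saturated chain carbon. Among the measured compounds shown here, compound 1 also carries phenyl, but its chain differs too, and no measured pair isolates this change. In this assay, no step beyond the scatter is expected in either direction. The expected step is a 1.1-fold lower number from compound 2 to compound 3 (0.04 log units; within the scatter). For compound 3, the estimated half-life is 0.7 h, with an expected range of 0.35 h to 1.4 h.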

Compound 3, half-life: 1.3 h
Compound 3: the middle estimate sits 1.9-fold (0.27 log units) below what was measured; the measured number falls inside the stated range.
By their numbers in this assay, from the lowest: compound 1; then compounds 2 and 3 (each within the scatter of the next).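

In this assay, phenyl in place of furan-2-yl on the saturated chain carbon gives a 1.7-fold higher number from compound 2 to compound 3 (0.23 log units; within the scatter), so the two compounds are not separated by this exchange of rings. Among the compounds shown here, with phenyl held constant, trifluoromethyl in place of cyano gives a 3.5-fold higher number from compound 1 to compound 3 (0.54 log units; beyond the scatter), the only step here that exceeds the scatter, which places the clear difference at the end of the chain rather than at the ring. Nothing at hand explains either step. The compounds shown leave open how an amine or a carboxylic acid at the end of the chain would read, and whether a longer chain would keep the half-life of compound 3.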